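Cyclohex-1-en-1-yl replaces 3-fluorophenyl on the shared core

The source may report more compounds than this note shows. Statements on the series, on what has been measured and on what is new or still open speak of the compounds shown alone.

Measured in an ADME assay (liver) for metabolic stability, with Liver microsome (Rattus norvegicus) as the target, using microsomes; a lower number here means slower removal, a higher number faster removal of the compound:
Compound 1 `O=C(O)c1csc(-n2nc(-c3ccccc3)c3ccc(O)cc32)n1`: 522 mL/min/kg
Compound 2 `O=C(O)c1csc(-n2nc(-c3cccc(F)c3)c3ccccc32)n1`: 385 mL/min/kg

In this assay, compound 2 gives 385 mL/min/kg, which lies within the usual scatter of compound 1 at 522 mL/min/kg. Compound 3 `O=C(O)c1csc(-n2nc(C3=CCCCC3)c3ccccc32)n1`, not yet measured, has cyclohex-1-en-1-yl in place of 3-fluorophenyl on an aromatic carbon. Among the compounds with values here, no measured pair shows what such a swap does, so no change beyond the scatter is expected in this assay. The expected step is small, a 1.0-fold higher number from compound 2 to compound 3 (0.02 log units; within the scatter). For compound 3 the estimated clearance is 400 mL/min/kg, with a likely range of 200 mL/min/kg to 800 mL/min/kg.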

Compound 3, clearance: 490 mL/min/kg
For compound 3 the middle estimate is 1.2-fold (0.09 log units) below the measured one; measured number inside the range.
By their numbers in this assay, from the lowest: compounds 2, 3 and 1 (each within the scatter of the next).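

In this assay, within the data shown here, putting cyclohex-1-en-1-yl in place of 3-fluorophenyl on this aromatic carbon gives a 1.3-fold higher number from compound 2 to compound 3 (0.10 log units; within the scatter), the first reading for a change at this position. Here, this read-out does not separate a fluorine-bearing aromatic ring from a non-aromatic carbon ring with one double bond. Nothing available explains this result. On these data alone, both groups are six-membered carbon rings without hydrogen-bond donors or acceptors, so the effect of a different kind of group remains unknown. An amine or a longer chain at this position could show whether this assay responds to such a change.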